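Benzyl-thioether series: removing the ortho-chloro substituent

The compounds below may be only part of what the source reports. "The series", "measured", "known", "first", "only" and "open" are said of these compounds alone.

Measured so far in a functional assay on HepG2 cells (Homo sapiens) for inhibition, read by MTT assay, with a stated time of 48 h; a higher number here means a weaker inhibitor, a lower number a stronger inhibitor:
compound 1 `Clc1ccccc1CSc1nnc(-c2ccncc2)n1-c1ccccc1` — 15700 nM
compound 2 `Brc1cccc(CSc2nnc(-c3ccncc3)n2-c2ccccc2)c1` — 7040 nM
compound 3 `Fc1cccc(F)c1CSc1nnc(-c2ccncc2)n1-c1ccccc1` — a limit, > 50000 nM

Compound 1 stands as the higher of the two numbers measured in this assay; the nearest is compound 2, reached by a 2.2-fold lower number from compound 1 to compound 2 (0.35 log units; beyond the scatter). Compound 3 sits at a limit of the assay and gives no number, (the limit of > 50000 nM in this assay, at which 1 of the 3 values shown sits); the step of an at least 3.1-fold higher number from compound 1 to compound 3 (0.50 log units; beyond the scatter) and the step of an at least 7.1-fold higher number from compound 2 to compound 3 (0.85 log units; beyond the scatter) are therefore lower bounds.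

Compound 4 `c1ccc(CSc2nnc(-c3ccncc3)n2-c2ccccc2)cc1` differs from compound 1 by hydrogen in place of chloro on an aromatic carbon. Within the data shown here, none of the measured steps removes a halogen outright: one swaps chloro for bromo and moves it, the other adds fluorines. Both halogen changes moved the number beyond the scatter, so the loss of the chloro is expected to matter, and the direction taken from compound 3 suggests that a changed halogen pattern on this ring more readily weakens than strengthens. Compound 4 is expected to be a somewhat weaker inhibitor, with a 1.6-fold higher number from compound 1 to compound 4 (0.20 log units; within the scatter); the estimate for compound 4 in this assay is 25000 nM, within 8000 nM to 80000 nM, with a real chance that only a limit is returned.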

Compound 4, half-maximal inhibitory concentration: 12900 nM
Estimate against measurement, compound 4: 1.9-fold (0.29 log units) above, and the stated range covers the measured number.
By their numbers in this assay, from the lowest: compounds 2, 4 and 1 (each within the scatter of the next, the first and the last beyond it). At a limit, above all of these: compound 3.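

In this assay, hydrogen in place of chloro gives a 1.2-fold lower number from compound 1 to compound 4 (0.09 log units; within the scatter), and hydrogen in place of bromo gives a 1.8-fold higher number from compound 2 to compound 4 (0.26 log units; within the scatter), so neither halogen is needed on this ring to hold the level seen with compound 1 and compound 2. Against the unsubstituted phenyl, the 2,6-difluorophenyl group stands apart, with an at least 3.8-fold lower number from compound 3 to compound 4 (0.58 log units; beyond the scatter), so in this set the weakening belongs to that pattern and not to the removal of a halogen. Compound 3 remains a limit of the assay, which makes that step a lower bound: the limit of > 50000 nM in this assay, at which 1 of the 4 values shown sits.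

Open, going by these compounds, is whether a single fluoro on this ring behaves like chloro and bromo or already weakens like the 2,6-difluorophenyl pattern. Also open, on these data alone, is how a methoxy, an amine or a carboxylic acid on this ring, or a longer chain in place of the saturated carbon bound to the sulfur, would read.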